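The compounds below may be only part of what the source reports. "The series", "measured", "known", "first", "only" and "open" are said of these compounds alone.

Compound 1 `O=C(NCc1ccc(CNS(=O)(=O)c2ccccc2F)cc1)c1ccc(CNc2ncccn2)cc1` sets the starting point: in an assay on MDA-MB-231 cells for binding affinity to C-X-C chemokine receptor type 4 (Homo sapiens), read by microscopy, with stated times of 10 min and 30 min (a lower number here means that less compound is needed, a higher number that more compound is needed for the effect), compound 1 gives 1000 nM. Compound 2 `O=C(NCc1ccc(CNS(=O)(=O)c2ccc(F)c(F)c2)cc1)c1ccc(CNc2ncccn2)cc1` is measured in the same way, and compound 2 gives 100 nM. The step of a 10-fold lower number from compound 1 to compound 2 (1.00 log units; beyond the scatter) is a change of one fluorinated ring for another on the sulfonyl sulfur. Compound 3 `O=C(NCc1ccc(CNS(=O)(=O)c2ccc(F)cc2)cc1)c1ccc(CNc2ncccn2)cc1` returns only a limit of this assay, and compound 3 gives > 1000 nM. That limit is described in the limit of > 1000 nM in this assay, at which 1 of the 3 values shown sits. So compound 3 stands not at a number but at the edge of what the assay reports: the step of a number no lower from compound 1 to compound 3 (the limit leaves the size open) cannot be sized, while the step of an at least 10-fold higher number from compound 2 to compound 3 (1.00 log units; beyond the scatter) shows how much the fluoro on an aromatic carbon mattered.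

Compound 4 `O=C(NCc1ccc(CNS(=O)(=O)c2cccnc2)cc1)c1ccc(CNc2ncccn2)cc1` differs from compound 3 in one place: pyridin-3-yl in place of 4-fluorophenyl on a sulfonyl sulfur. Going by the values given here, no measured step exchanges the whole ring on the sulfonyl sulfur for a ring with a nitrogen, so the three steps above only show that changes on this ring can move the number at least modestly, and the step from compound 3 to compound 4 has no direct precedent. Compound 4 is therefore expected to stay near the same region, with a number no higher from compound 3 to compound 4 (the limit leaves the size open), giving an estimated 1000 nM within 200 nM to 5000 nM.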

Compound 4, effective concentration (reported as EC, without a stated level of effect): > 1000 nM
Compound 4: no number, only a limit (the forecaster's own chance of this, stated with the estimate: 50%); the middle value sits exactly at the limit.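

In this assay compound 4 gives > 1000 nM, which is a limit of the assay and not a number. A ring with a nitrogen on the sulfonyl sulfur, pyridin-3-yl with its one hydrogen-bond acceptor, therefore does not reach the level seen with 3,4-difluorophenyl, as shown by an at least 10-fold higher number from compound 2 to compound 4 (1.00 log units; beyond the scatter). Against 2-fluorophenyl, the data give a number no lower from compound 1 to compound 4 (the limit leaves the size open). The step to compound 4 from compound 3 cannot be read, but a second, different ring on the sulfonyl sulfur now joins 4-fluorophenyl at the same edge of what the assay reports: the limit of > 1000 nM in this assay, at which 2 of the 4 values shown sit.

Going by these compounds, how far compound 3 and compound 4 lie beyond that limit remains unknown, so no order can be given between 4-fluorophenyl and pyridin-3-yl. The compounds shown also leave open whether other groups on the sulfonyl sulfur, such as a phenyl ring carrying chlorine or methoxy, a cyclohexyl ring or a short alkyl chain, would come close to compound 2 or stay at the same limit.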